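A few compounds are considered here, and "the series" means these few. Any claim that something is new, unique, unknown or untested is made for them only; others in the source may bear on it.

In a functional assay on HEp-2 cells (Homo sapiens) for inhibition, with a stated time of 48 h, tested at 30 uM (on this read-out higher numbers stand for more inhibition of growth at the one concentration tested and lower numbers for less inhibition of growth), compound 1 (`C=C[C@@](C)(/C=C/c1ccc(OC(C)=O)cc1)CCC=C(C)C`) reaches 51% of inhibition, compound 2 (`C=C[C@@](C)(/C=C/c1ccc(OC(=O)CCCCCCCCC)cc1)CCC=C(C)C`) reaches 16% of inhibition, and compound 3 (`C=C[C@@](C)(/C=C/c1ccc(OC)cc1)CCC=C(C)C`) reaches 22% of inhibition. Compound 3 therefore lies within the scatter of compound 2, and both stand clearly under compound 1. Compound 4 (`COc1ccc(/C=C/[C@](C)(/C=C/c2ccc(O)cc2)CCC=C(C)C)cc1`) keeps the methyl on oxygen found in compound 3 but differs elsewhere. Its change is 2-(4-hydroxyphenyl)ethenyl in place of vinyl on a saturated chain carbon bound to a double-bonded chain carbon and two saturated chain carbons and this means 2-(4-hydroxyphenyl)ethenyl in place of vinyl on a saturated chain carbon bound to a double-bonded chain carbon and two saturated chain carbons. For the measured compounds named here, no measured step touches that place. The two available steps are a number 35 percentage points lower from compound 1 to compound 2 (beyond the scatter) for octyl in place of hydrogen and a number 29 percentage points lower from compound 1 to compound 3 (beyond the scatter) for methyl in place of acetyl. Both are sizeable, which shows that numbers in this small set can move a long way, but both concern a different place on the molecule. They give no direction for the new change, so the expectation stays close to the starting value with a wide margin. The step expected in this assay is a number 6 percentage points higher from compound 3 to compound 4 (within the scatter) and it is not expected to pass beyond the scatter. The estimate for compound 4 is 28% with an expected range from 10% to 50% once it is measured.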

Compound 4, percent growth inhibition at one concentration: 45%
Compound 4: the middle estimate sits 17 percentage points below what was measured, within the range that was stated.
By their numbers in this assay, from the lowest: compounds 2 and 3 (each within the scatter of the next); then compounds 4 and 1 (each within the scatter of the next).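

Until this point, the only changes shown were to the group on the oxygen of the aromatic ring, so this is the first reading at the saturated chain carbon that carries the vinyl group. In this assay, 2-(4-hydroxyphenyl)ethenyl in place of vinyl gives a number 23 percentage points higher from compound 3 to compound 4 (beyond the scatter), which shows that this position accepts a much bigger group and that, in this one pair, the bigger group goes with more inhibition of growth. The entering group brings in an aromatic ring, a hydroxyl group and a longer reach all at once, and nothing available explains the rise or ties it to any one of these parts.

Still open, from the compounds shown here alone, is whether the ring alone is enough, which a plain 2-phenylethenyl group in the same place could test, and whether the hydroxyl group matters, which an amine or a carboxylic acid on that ring could help to show. Also open, going by these compounds, is whether the same change would give a similar step on the core of compound 1, which carries acetyl rather than methyl on the oxygen.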